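Working notes: from the halogen pair to compound 3

This account rests on a few compounds, and the source may have more. Where it says the series, first, only, none or still open, it means among the compounds named here.

Going by the values given here, in a functional assay on NCI-H460 cells (Homo sapiens) for inhibition, read by sulforhodamine B assay, with a stated time of 48 h (on this read-out higher numbers stand for weaker inhibition of growth and lower numbers for stronger inhibition of growth), compound 1 (`Ic1ccc(Cn2cc(CCCOc3cccc4cccnc34)nn2)cc1`) reads 24.6 ug/mL and compound 2 (`Brc1ccc(Cn2cc(CCCOc3cccc4cccnc34)nn2)cc1`) reads 11.7 ug/mL as the lowest of the two numbers so far. Among the compounds with values here, the only measured step (a 2.1-fold lower number from compound 1 to compound 2 (0.32 log units; beyond the scatter)) is modest and places bromo in place of iodo on an aromatic carbon.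

Compound 3 (`c1cncc(CCCn2cc(CCCOc3cccc4cccnc34)nn2)c1`) differs from compound 2 by a larger change (2-(pyridin-3-yl)ethyl in place of 4-bromophenyl on a saturated chain carbon bound to an aromatic nitrogen), with 2-(pyridin-3-yl)ethyl in place of 4-bromophenyl on a saturated chain carbon bound to an aromatic nitrogen. The halogen step bears on this only loosely, since it keeps the 4-substituted benzyl arm and swaps one halogen for another. Within the data shown here, no measured compound lacks the halogen or carries a hetero atom in that ring, so the size of the new step is poorly defined.

Among the measured compounds shown here, with compound 2 at 11.7 ug/mL as the lower of only two numbers, a modest step to a higher number is expected in this assay, similar in size to the halogen step. An estimated step (a 2.1-fold higher number from compound 2 to compound 3 (0.33 log units; beyond the scatter)) is expected. For compound 3 an estimated 25 ug/mL is expected (range 9 ug/mL to 70 ug/mL).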

Compound 3, concentration for 50% growth inhibition: 44.3 ug/mL
Estimate against measurement, compound 3: 1.8-fold (0.25 log units) below; measured number inside the range.
By their numbers in this assay, from the lowest: compound 2; then compounds 1 and 3 (each within the scatter of the next).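

In this assay, the exchange of 4-bromobenzyl for 3-(pyridin-3-yl)propyl on the saturated chain carbon bound to an aromatic nitrogen gives a 3.8-fold higher number from compound 2 to compound 3 (0.58 log units; beyond the scatter) and so shows that this position responds to a change of the whole arm, not only to a swap of halogen. Set against the iodo analogue, the same arm gives a 1.8-fold higher number from compound 1 to compound 3 (0.26 log units; within the scatter) and so cannot be separated from it, which leaves compound 2 as the only one of the three standing apart, with the strongest inhibition of growth in this small set. Nothing measured alongside these numbers accounts for them.

The exchange alters the aromatic ring and the length of the chain at once, so the compounds shown leave open which of the two carries the step from the bromo compound. A pyridin-3-ylmethyl arm or a 3-phenylpropyl arm would separate the two, and a chloro or fluoro group on the benzyl ring would show whether the halogen step extends beyond bromo and iodo.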